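A few compounds are considered here, and "the series" means these few. Any claim that something is new, unique, unknown or untested is made for them only; others in the source may bear on it.

Compound 1 `C/C(=C\c1cc(-c2ccccc2)cs1)C(N)=O` is one of three close analogues examined in a functional assay on HO8910 cells (Homo sapiens) for cytotoxicity, read by CCK-8 assay, with a stated time of 24 h; on this read-out lower numbers stand for stronger inhibition and higher numbers for weaker inhibition. In this assay compound 1 gives > 50000 nM, which is a limit of the assay rather than a number. Compound 2 `C/C(=C\c1cc(-c2ccc(C)cc2)cs1)C(N)=O` gives > 50000 nM, likewise a limit. Compound 3 `C/C(=C\c1cc(-c2ccc(F)cc2)cs1)C(N)=O` gives > 50000 nM, also a limit. Because of the limit of > 50000 nM in this assay, at which 3 of the 3 values shown sit, the steps a step that the two limits leave unreadable from compound 1 to compound 2 and a step that the two limits leave unreadable from compound 1 to compound 3 cannot be sized, and neither can a step that the two limits leave unreadable from compound 2 to compound 3. Compound 4 `C/C(=C\c1cc(-c2ccccc2C)cs1)C(N)=O` differs from compound 1 by methyl in place of hydrogen on an aromatic carbon. The measured steps that resemble it, a methyl or fluoro in place of hydrogen on an aromatic carbon, gave no readable size, so no step beyond the scatter can be drawn from them. Compound 4 is therefore expected to sit near the limit as well, at an estimated 80000 nM with a range from 30000 nM to 300000 nM. The step that the limit leaves unreadable from compound 1 to compound 4 is expected to lie within the scatter.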

Compound 4, half-maximal inhibitory concentration: 15200 nM
For compound 4 the middle estimate is 5.3-fold (0.72 log units) above the measured one; measured number below the stated range.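

In this assay, among these compounds, methyl in place of hydrogen on an aromatic carbon, ortho to a large group, gives an at least 3.2-fold lower number from compound 1 to compound 4 (0.51 log units; beyond the scatter), the first step that can be sized. Compound 2, which also carries a methyl in place of hydrogen on an aromatic carbon, remains at a limit of the assay, > 50000 nM. Methyl alone therefore does not yield a readable number; its place on the ring matters.

As far as these compounds go, it remains open whether ethyl, methoxy or an amine at this place would lower the number further. From the compounds shown here alone, the true size of the step also stays unknown, as compound 1 has only a limit.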